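The source may report more compounds than this note shows. Statements on the series, on what has been measured and on what is new or still open speak of the compounds shown alone.

Measured so far:

Compound 1, `O=C(NCc1ccc(F)cc1)c1ncc([N+](=O)[O-])[nH]1`: in a toxicity assay on HepG2 cells (Homo sapiens) for inhibition, read by resazurin assay, with a stated time of 24 h (a higher number here means that more compound is tolerated, a lower number that less compound is tolerated), compound 1 gives > 100000 nM, which is a limit of the assay rather than a number.

Compound 2, `O=C(NCc1ccc(OC(F)(F)F)cc1)c1ncc([N+](=O)[O-])[nH]1`: in this assay compound 2 gives 93000 nM.

Compound 3, `NC(=O)c1nc([N+](=O)[O-])cn1Cc1ccc(F)cc1`: in this assay compound 3 gives > 100000 nM, again a limit of the assay and not a number.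

Compound 1 and compound 2 share a core and differ in a single place: trifluoromethoxy in place of fluoro on an aromatic carbon. The measured step is an at least 1.0-fold lower number from compound 1 to compound 2 (0.03 log units; that floor lies within the scatter), so the two results cannot be told apart; neither compound shows more or less tolerance than the other within the scatter of the assay.

Compound 3 is built from the same atoms as compound 1, joined differently; the difference between the two cores is not broken down here. Compound 4, `NC(=O)c1nc([N+](=O)[O-])cn1Cc1ccc(OC(F)(F)F)cc1`, has not yet been measured. It stands to compound 3 exactly as compound 2 stands to compound 1, the same change made on the other core: trifluoromethoxy in place of fluoro on an aromatic carbon.

Within the data shown here, the only guide to compound 4 is that pair. Because the step of an at least 1.0-fold lower number from compound 1 to compound 2 (0.03 log units; that floor lies within the scatter) stayed within the scatter, the same change on compound 3 is expected to leave the result essentially where compound 3 sits. Because of the limit of > 100000 nM in this assay, at which 2 of the 3 values shown sit, a limit rather than a number is also the more likely outcome. Compound 4 is therefore expected to show a number no higher from compound 3 to compound 4 (the limit leaves the size open). The estimate for compound 4 is 100000 nM. For compound 4 the expected range runs from 50000 nM to 200000 nM.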

Compound 4, half-maximal cytotoxic concentration: > 100000 nM
Compound 4: no number, only a limit; the forecaster's own chance of this, stated with the estimate: 60%; the middle value lies on the limit itself.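

Compound 3 and compound 4 both stop at a limit of this assay rather than at a number, so the step between them cannot be read. Such limits dominate these results: the limit of > 100000 nM in this assay, at which 3 of the 4 values shown sit. The compounds shown leave open how much of compound 3 or compound 4 the cells tolerate, and whether trifluoromethoxy in place of fluoro makes any difference on this core.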